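The compounds below may be only part of what the source reports. "The series", "measured", "known", "first", "only" and "open" are said of these compounds alone.

Compound 1 `CC1(C)CC(=O)c2sc(NC(=O)c3cc4ccccc4s3)nc2C1`: 65400 nM
Compound 2 `CC1(C)CC(=O)c2sc(NC(=O)c3sc4c(Br)cccc4c3Cl)nc2C1`: 25200 nM
Compound 3 `CC1(C)CC(=O)c2sc(NC(=O)c3nc4ccccc4s3)nc2C1`: 30400 nM

In an ADME assay on L6 cells (Rattus norvegicus) for cytotoxicity, read by fluorescence and resazurin assay, with a stated time of 70 h (a higher number here means a weaker inhibitor, a lower number a stronger inhibitor), compound 1 gives the highest of these three numbers, and both compound 2 and compound 3 lie lower by more than the usual scatter. Compound 4 `COc1cccc2cc(C(=O)Nc3nc4c(s3)C(=O)CC(C)(C)C4)sc12` differs from compound 1 in one place: methoxy in place of hydrogen on an aromatic carbon. Going by the values given here, no measured pair shows this change on its own, so the expectation is loose. Compound 2, which carries added groups, gives 25200 nM, a lower number than compound 1, and this hints at a modest drop. The expected change is small and downward, a 1.6-fold lower number from compound 1 to compound 4 (0.21 log units; within the scatter), and may not exceed the scatter. The estimate for compound 4 is 40000 nM, with an expected range from 18000 nM to 85000 nM.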

Compound 4, half-maximal inhibitory concentration: 54500 nM
Beside the measured number, compound 4's estimate is 1.4-fold (0.13 log units) below it; measured number inside the range.
By their numbers in this assay, from the lowest: compounds 2, 3, 4 and 1 (each within the scatter of the next, the first and the last beyond it).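

Methoxy in place of hydrogen on an aromatic carbon gives a 1.2-fold lower number from compound 1 to compound 4 (0.08 log units; within the scatter) in this assay and so leaves the two compounds indistinguishable. Going by these compounds alone, this is the first comparison here that isolates a single change, and it shows that this carbon of the six-membered ring can carry methoxy without a readable shift in this assay. Nothing available explains this result.

As far as these compounds go, whether a hydroxyl group, an amine or a fluorine atom on this same carbon would behave alike remains open. So does the effect of methoxy on the other carbons of this ring.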